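Methyl in Place of Trifluoromethyl on the Sulfonamide Ring

This account rests on a few compounds, and the source may have more. Where it says the series, first, only, none or still open, it means among the compounds named here.

Measured compounds:
compound 1, `Cc1cc(Cl)cc(Cl)c1S(=O)(=O)N1CCC(N2CCC(C)CC2)CC1`, 0.6 nM
compound 2, `CC1CCN(C2CCN(S(=O)(=O)c3cccc(C(F)(F)F)c3)CC2)CC1`, > 5000 nM
compound 3, `COc1ccccc1-c1ccc(S(=O)(=O)N2CCC(N3CCC(C)CC3)CC2)cc1`, 26 nM

Of the compounds shown here, three sharing one core have been measured in a functional assay on DLD-1 cells (Homo sapiens) for antiproliferative activity, read by CellTiter-Glo, with a stated time of 72 h; a lower number here means a stronger inhibitor, a higher number a weaker inhibitor. Compound 1 gives 0.6 nM and compound 3 gives 26 nM. For compound 2 the assay reports only a limit, > 5000 nM, so compound 2 stands at the limit of > 5000 nM in this assay, at which 1 of the 3 values shown sits, and no number for it is known.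

Compound 4, `Cc1cccc(S(=O)(=O)N2CCC(N3CCC(C)CC3)CC2)c1`, has not yet been measured. It differs from compound 2 in one place: methyl in place of trifluoromethyl on an aromatic carbon. Among the compounds with values here, no two measured compounds differ in only one place, so no measured step shows what this exchange does. Both compounds that carry no trifluoromethyl, compound 1 and compound 3, sit well inside the measurable range, while compound 2 does not. On that basis a move toward stronger inhibition is expected, estimated at an at least 10-fold lower number from compound 2 to compound 4 (1.00 log units; beyond the scatter), though with wide uncertainty. Compound 4 is expected to give 500 nM, within a range from 50 nM to 5000 nM.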

Compound 4, half-maximal inhibitory concentration: 25 nM
Beside the measured number, compound 4's estimate is 20-fold (1.30 log units) above it, outside the stated range (below it).
By their numbers in this assay, from the lowest: compound 1; then compounds 4 and 3 (each within the scatter of the next). At a limit, above all of these: compound 2.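

In this assay, within the data shown here, this is the first pair of compounds that differ in only one place, and it shows that methyl in place of trifluoromethyl on this aromatic carbon gives an at least 200-fold lower number from compound 2 to compound 4 (2.30 log units; beyond the scatter). The value for compound 2 is a limit of the assay, not a number, so this step gives only a minimum size: the limit of > 5000 nM in this assay, at which 1 of the 4 values shown sits. Even so, this one exchange takes the compound from a limit to a measurable value, so activity in this assay depends strongly on which of these two groups sits at this position.

The compounds shown do not explain why the exchange has so large an effect. They also leave open what a nitrile, an amine or a carboxylic acid would give at this position, and whether the same exchange would matter as much elsewhere on the ring.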